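Thiophen-3-yl for 4-fluorophenyl: cytotoxicity notes

A few compounds are considered here, and "the series" means these few. Any claim that something is new, unique, unknown or untested is made for them only; others in the source may bear on it.

Values in an ADME assay on BJ cells (Homo sapiens) for cytotoxicity, read by MTT assay, with a stated time of 72 h; a lower number here means that less compound is tolerated, a higher number that more compound is tolerated:
- compound 1 `OC[C@H]1O[C@@H](n2cc(F)c3c(-c4nccs4)ncnc32)[C@H](O)[C@@H]1O`: 630 nM
- compound 2 `OC[C@H]1O[C@@H](n2cc(F)c3c(-c4c[nH]cn4)ncnc32)[C@H](O)[C@@H]1O`: > 50000 nM (a limit of the assay)
- compound 3 `OC[C@H]1O[C@@H](n2cc(Cl)c3c(-c4ccc(F)cc4)ncnc32)[C@H](O)[C@@H]1O`: 49500 nM

In this assay, compound 3 gives 49500 nM, the higher of the two actual numbers and well clear of compound 1 at 630 nM. Compound 2 reads > 50000 nM, which is a limit and not a number.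

Compound 4 `OC[C@H]1O[C@@H](n2cc(Cl)c3c(-c4ccsc4)ncnc32)[C@H](O)[C@@H]1O` replaces 4-fluorophenyl with thiophen-3-yl on an aromatic carbon: thiophen-3-yl in place of 4-fluorophenyl on an aromatic carbon.

Among the compounds with values here, no measured step starts from compound 3, so the evidence is indirect. Within the data shown here, the one measured step, an at least 79-fold higher number from compound 1 to compound 2 (1.89 log units; beyond the scatter), is large and beyond the scatter. It shows that exchanging one five-membered aromatic group for another can shift this read-out strongly. The sulfur-bearing ring of thiophen-3-yl resembles the 1,3-thiazol-2-yl group of compound 1 at 630 nM, although compound 1 also differs from compound 3 elsewhere. A large move towards a lower number is therefore expected, with wide uncertainty, as a 17-fold lower number from compound 3 to compound 4 (1.22 log units; beyond the scatter) in estimated terms.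

For compound 4, the estimated value is 3000 nM, with an expected range from 300 nM to 40000 nM.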

Compound 4, half-maximal cytotoxic concentration: 1720 nM
Beside the measured number, compound 4's estimate is 1.7-fold (0.24 log units) above it; the measured number falls inside the stated range.
By their numbers in this assay, from the lowest: compound 1; then compound 4; then compound 3. At a limit, above all of these: compound 2.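

In this assay, the position on the six-membered aromatic ring with 2 nitrogen now has a measured step in the chlorine-bearing compounds, a 29-fold lower number from compound 3 to compound 4 (1.46 log units; beyond the scatter), so a large shift here is not confined to the fluorine-bearing pair. This step also differs in kind from the earlier one: a six-membered aromatic ring of carbon only leaves and a five-membered aromatic ring with 1 hetero atom enters, whereas an at least 79-fold higher number from compound 1 to compound 2 (1.89 log units; beyond the scatter) exchanged one five-membered aromatic group for another. In both steps the compound carrying the sulfur-bearing ring has the lower number, and neither of the two steps goes against this, although the second step in that pair ends at a limit of the assay rather than a number: the limit of > 50000 nM in this assay, at which 1 of the 4 values shown sits.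

Because thiophen-3-yl differs from 4-fluorophenyl in ring size, in ring atoms and in the loss of fluorine all at once, the step does not say which of these changes carries the shift; furan-3-yl or unsubstituted phenyl at this place would help to separate them. Also open are how an amine or a carboxylic acid on the ring at this place would read, and whether the fluorine or chlorine on the shared core matters, since no pair shown differs there alone.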